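Dichlorophenyl swap in a narrow cytotoxicity series

The source may hold more compounds than are shown below. What is called first, only, known or untested is meant among the compounds shown, and "the series" means these compounds.

Three compounds with a shared core have values in a functional assay on HT-1080 cells (Homo sapiens) for cytotoxicity, read by MTT assay, with a stated time of 72 h; a higher number here means a weaker inhibitor, a lower number a stronger inhibitor: compound 1 (`COc1cccc(/C=C2\CCC/C(=C\c3ccc(Cl)cc3)C2=O)c1OC`) gives (11100 nM), compound 2 (`COc1cccc(/C=C2\CCC/C(=C\c3cccc(OC)c3OC)C2=O)c1`) gives (9900 nM) and compound 3 (`COc1cccc(/C=C2\CCC/C(=C\c3cccc(Cl)c3Cl)C2=O)c1OC`) gives (19300 nM). Compound 3 lies within the scatter of both others, so no order can be read among the three.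

Compound 4 (`COc1cccc(/C=C2\CCC/C(=C\c3cc(Cl)cc(Cl)c3)C2=O)c1OC`) has 3,5-dichlorophenyl in place of the 2,3-dichlorophenyl of compound 3, on a double-bonded chain carbon bound to a double-bonded ring carbon (3,5-dichlorophenyl in place of 2,3-dichlorophenyl on a double-bonded chain carbon bound to a double-bonded ring carbon). Three measured steps at this same place bear on the change: (a 1.7-fold higher number from compound 1 to compound 3 (0.24 log units; within the scatter)), (a 1.9-fold higher number from compound 2 to compound 3 (0.29 log units; within the scatter)) and (a 1.1-fold lower number from compound 1 to compound 2 (0.05 log units; within the scatter)). All three lie within the scatter, although none of them involves the 3,5-dichlorophenyl group itself, so the data offer only indirect support. Swaps at this place have so far left the values within the scatter, so no step beyond the scatter is expected in this assay, and no firm direction is expected either. The estimated change is (a 1.5-fold lower number from compound 3 to compound 4 (0.17 log units; within the scatter)), which is expected to stay within the scatter. For compound 4 the expected value is 13000 nM (estimated range 6500 nM to 26000 nM).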

Compound 4, half-maximal inhibitory concentration: 6100 nM
Compound 4: the middle estimate sits 2.1-fold (0.33 log units) above what was measured, and the stated range ends above it.
By their numbers in this assay, from the lowest: compounds 4, 2, 1 and 3 (each within the scatter of the next, the first and the last beyond it).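

In this assay, within the data shown here, 3,5-dichlorophenyl in place of 2,3-dichlorophenyl gives the first step beyond the scatter at this place, though a modest one (a 3.2-fold lower number from compound 3 to compound 4 (0.50 log units; beyond the scatter)). The two groups have the same atoms, joined differently, and the same counts under every heading compared, so rearranging the phenyl substitution alone is enough to separate two compounds in this series, which no earlier swap of 4-chlorophenyl, 3-methoxyphenyl and 2,3-dichlorophenyl had done. The separation holds only for that pair, since compound 4 stays within the scatter of the other two (a 1.6-fold lower number from compound 2 to compound 4 (0.21 log units; within the scatter); a 1.8-fold lower number from compound 1 to compound 4 (0.26 log units; within the scatter)), and nothing available accounts for the step.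

Going by these compounds, the series still rests on a single step beyond the scatter, so it remains open whether this reflects a wider trend at this place or is specific to the 2,3-dichlorophenyl and 3,5-dichlorophenyl pair. Also open is how an amine or a carboxylic acid on the phenyl at this place would read in this assay, as the groups shown carry only chlorine or methoxy.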